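Exchanging the Group on the Sulfonyl Sulfur of Compound 3

This account rests on a few compounds, and the source may have more. Where it says the series, first, only, none or still open, it means among the compounds named here.

Measured in a functional assay on HEK293 cells (Homo sapiens) for cytotoxicity; on this read-out lower numbers stand for higher toxicity in this test and higher numbers for lower toxicity in this test:
- compound 1 `COc1ccc([C@H]2CC(=O)N(c3cccc(NC(=O)C(C)=O)c3)C2)cc1OC1CCCC1`: > 10000 nM, a limit
- compound 2 `COc1ccc(OC)c(S(=O)(=O)Nc2cccc(N3C[C@@H](c4ccc(OC)c(OC5CCCC5)c4)CC3=O)c2)c1`: 7590 nM
- compound 3 `COc1ccc([C@H]2CC(=O)N(c3cccc(NS(=O)(=O)c4cccc(Cl)c4C)c3)C2)cc1OC1CCCC1`: > 10000 nM, a limit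

Compound 3 has only a limit and no number, and it stands with the limit of > 10000 nM in this assay, at which 2 of the 3 values shown sit. Compound 4 `COc1ccc([C@H]2CC(=O)N(c3cccc(NS(=O)(=O)c4ccccc4Br)c3)C2)cc1OC1CCCC1` carries 2-bromophenyl in place of 3-chloro-2-methylphenyl on a sulfonyl sulfur. The nearest measured change, at the same sulfonyl sulfur, is an at least 1.3-fold higher number from compound 2 to compound 3 (0.11 log units; that floor lies within the scatter). The other change is a step that the two limits leave unreadable from compound 1 to compound 3. Neither shows a size beyond the scatter, so none is expected here in this assay. The expected step is a number no higher from compound 3 to compound 4 (the limit leaves the size open). Compound 4 is estimated at 10000 nM, with an expected range of 5000 nM to 20000 nM.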

Compound 4, half-maximal cytotoxic concentration: > 10000 nM
Compound 4: only a limit was reported (the forecaster's own chance of this, stated with the estimate: 70%); the middle value sits exactly at the limit.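

With 2-bromophenyl on the sulfonyl sulfur, compound 4 stands at a limit in this assay, so a second halogen-bearing phenyl group at this position also gives no number: the limit of > 10000 nM in this assay, at which 3 of the 4 values shown sit. The steps from compound 3 and from compound 1 to compound 4 cannot be read, as both ends are limits. For the compounds shown here, the only readable comparison is an at least 1.3-fold higher number from compound 2 to compound 4 (0.11 log units; that floor lies within the scatter), so the exchange shows no change beyond the scatter.

Going by these compounds, what remains open is whether any group on this sulfur gives a readable number among the limits. An amine or a carboxylic acid on the phenyl ring could test that.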